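The source may report more compounds than this note shows. Statements on the series, on what has been measured and on what is new or still open speak of the compounds shown alone.

Measured compounds:
compound 1 `COc1cc(OC)c(C(=O)/C=C/c2ccc(O)cc2)c(OC)c1`, 40600 nM in a functional assay on HeLa cells (Homo sapiens) for inhibition, read by MTT assay, with a stated time of 72 h; on this read-out higher numbers stand for weaker inhibition and lower numbers for stronger inhibition
compound 2 `COc1cc(OC)c(C(=O)/C=C/c2ccc(O)c(O)c2)c(OC)c1`, 15800 nM

Compound 2 holds the lowest of the two numbers in this assay; its nearest neighbour is compound 1, whose number is higher. For the measured compounds named here, the single measured step is a 2.6-fold lower number from compound 1 to compound 2 (0.41 log units; beyond the scatter), brought about by hydroxy in place of hydrogen on an aromatic carbon.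

Compound 3 `COc1cc(OC)c(C(=O)/C=C/c2ccc(O)c(OC)c2)c(OC)c1` is the next compound, as yet unmeasured. It differs from compound 2 by methyl in place of hydrogen on an oxygen on an aromatic ring, that is, the hydroxy that enters between compound 1 and compound 2 is capped as methoxy. Going by the values given here, no measured pair shows this change directly; the only step that bears on it is the one from compound 1 to compound 2, which shows that the hydroxy itself lowers the number modestly. Capping it with methyl removes that hydroxy again, so part of the gain may be lost, and the expectation is a small step back toward the number of compound 1, possibly still within the scatter. The step from compound 2 to compound 3 is estimated as a 1.6-fold higher number from compound 2 to compound 3 (0.20 log units; within the scatter). Compound 3 is expected to give about 25000 nM, with a plausible range from 10000 nM to 60000 nM.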

Compound 3, half-maximal inhibitory concentration: 44900 nM
Estimate against measurement, compound 3: 1.8-fold (0.25 log units) below; the range from low to high includes it.
By their numbers in this assay, from the lowest: compound 2; then compounds 1 and 3 (each within the scatter of the next).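

In this assay, methyl in place of hydrogen on the oxygen gives a 2.8-fold higher number from compound 2 to compound 3 (0.45 log units; beyond the scatter), so the lower number of compound 2 is not kept once the hydroxy is capped as methoxy. Set against the compound with only hydrogen at that aromatic carbon, methoxy gives a 1.1-fold higher number from compound 1 to compound 3 (0.04 log units; within the scatter), which leaves compound 3 and compound 1 indistinguishable on this read-out. The earlier step could not tell whether any oxygen-linked group at this place would go with a lower number, whereas here the free hydroxy alone does, and methoxy does not separate from hydrogen.

Nothing shown accounts for this difference between hydroxy and methoxy. As far as these compounds go, it remains open whether an amine, a fluorine atom or a longer ether such as ethoxy at the same place would stand with compound 2 or with compound 1 and compound 3, and whether the hydroxy-to-methoxy difference would recur on a hydroxy elsewhere on the core of compound 1.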